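The source may report more compounds than this note shows. Statements on the series, on what has been measured and on what is new or still open speak of the compounds shown alone.

Working notes on the series. Three compounds have been run so far in an assay on HEK293 cells for positive allosteric modulation of metabotropic glutamate receptor 2 (Rattus norvegicus), read by thallium flux, with a stated time of 2.5 min; a higher number here means a larger maximal response, a lower number a smaller maximal response. Compound 2 `CCCC(=O)c1ccc(OCCCCOc2cccc(C(=O)O)c2C)c(C)c1O` gives 82.4% in this assay. Compound 3 `COc1cc(C(=O)O)ccc1OCCCCOc1ccc(C(=O)CC(C)C)c(O)c1C` gives 85.7%, a number that lies within the usual scatter of compound 2, so the two cannot be told apart on this read-out. Compound 1 `Cc1c(OCCCCOc2ccccc2C(=O)O)ccc(C(=O)CC2CCCC2)c1C` gives 67.1%, a number that sits beyond the scatter below compound 2; of the three, compound 2 therefore stands clearly above compound 1 and level with compound 3.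

The next compound in hand is compound 4 `Cc1c(OCCCCOc2ccc(C(=O)C(C)C)c(O)c2C)cccc1C(=O)O`, not yet measured in this assay. Compared with compound 2 the change is isopropyl in place of propyl on a carbonyl carbon, the two compounds having the same atoms joined differently. Among the measured compounds shown here, no pair of measured compounds differs in only one place, so there is no measured step to lean on for this change. The expectation is for no step beyond the scatter, with the maximal response of compound 4 expected to be about 80% (range 68% to 92%), that is, an expected step of a number 2.4 percentage points lower from compound 2 to compound 4 (within the scatter) in this assay.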

Compound 4, largest response reached (reported as percent of maximum), in percent of the reference or control that the assay uses: 66.9%
Compound 4: the middle estimate sits 13.1 percentage points above what was measured, outside the stated range (below it).
By their numbers in this assay, from the lowest: compounds 4 and 1 (each within the scatter of the next); then compounds 2 and 3 (each within the scatter of the next).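

In this assay, among the compounds shown here, isopropyl in place of propyl on a carbonyl carbon gives a number 15.5 percentage points lower from compound 2 to compound 4 (beyond the scatter), the first step that can be read at a single place. The two groups have the same count of heavy atoms, all carbon, and neither adds a ring, so the maximal response at this position depends on how the chain is joined and not on its atom count alone. No measurement at hand explains this step.

On these data alone, this finding rests on one pair, and whether the same change would give a similar step on the cores of compound 1 or compound 3 remains open. Also open, as far as these compounds go, is how a longer chain such as pentyl, or a cyclopropyl ring, on the same carbonyl carbon would behave.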